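Methoxy on the phenyl of compound 1

The source may hold more compounds than are shown below. What is called first, only, known or untested is meant among the compounds shown, and "the series" means these compounds.

Measured so far:
- compound 1 `O=C1CCc2cc(-c3csc(-c4ccccc4)n3)ccc2N1`: > 10000 nM
- compound 2 `COc1ccc(C(=O)c2nc(-c3ccc4c(c3)CCC(=O)N4)cs2)cc1OC`: 1000 nM
- compound 3 `COc1ccc(/C=C/c2nc(-c3ccc4c(c3)CCC(=O)N4)cs2)cc1OC`: 2800 nM

In a functional assay for inhibition, with Homo sapiens as the target (a higher number here means a weaker inhibitor, a lower number a stronger inhibitor), compound 1 reads > 10000 nM. That entry is a limit of the assay and not a number, so the position of compound 1 is known only as a bound.

Compound 4 `COc1ccc(-c2nc(-c3ccc4c(c3)CCC(=O)N4)cs2)cc1` is compound 1 with methoxy in place of hydrogen on an aromatic carbon, para to a large group, so that phenyl becomes 4-methoxyphenyl (methoxy in place of hydrogen on an aromatic carbon). Going by the values given here, no measured pair isolates this change. The nearest guide is that methoxy-bearing compounds give numbers: compound 2 gives 1000 nM and compound 3 gives 2800 nM. Both also differ from compound 4 in their linker and in carrying a further methoxy group, so the guide is loose.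

A shift toward a lower number in this assay is expected, of uncertain size, and compound 4 may yet reach the limit. The estimated step runs an at least 2.8-fold lower number from compound 1 to compound 4 (0.45 log units; beyond the scatter). For compound 4 the estimated value is 3500 nM, with an expected range of 1000 nM to 10000 nM.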

Compound 4, half-maximal inhibitory concentration: 9000 nM
Beside the measured number, compound 4's estimate is 2.6-fold (0.41 log units) below it; low and high end bracket the measured number.
By their numbers in this assay, from the lowest: compound 2; then compound 3; then compound 4. At a limit, above all of these: compound 1.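

In this assay compound 1 stands at > 10000 nM, a limit of the assay and not a number. Replacing phenyl with 4-methoxyphenyl gives a number instead of a limit, and the pair reads as an at least 1.1-fold lower number from compound 1 to compound 4 (0.04 log units; that floor lies within the scatter). That floor is all the pair fixes, so methoxy at this place is not shown to lower the number beyond the scatter, and the true size of the step stays unknown because one end of the pair is only a bound: the limit of > 10000 nM in this assay, at which 1 of the 4 values shown sits.

Open, from the compounds shown here alone, is whether an amine, a carboxylic acid or a longer alkoxy chain, para to a large group on the same ring, would read differently from methoxy. Also open, going by these compounds, is what a second methoxy does with the direct ring bond kept, since compound 2 and compound 3 each differ from compound 4 in more than one place.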